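A Sulfonamide Swap on a Shared Core

This account rests on a few compounds, and the source may have more. Where it says the series, first, only, none or still open, it means among the compounds named here.

Measured compounds:
compound 1 `CCOCCS(=O)(=O)N[C@@H](CNC(=O)c1ccc2c(c1)C(=O)N(CCC1CCNCC1)C2)C(=O)O` — 8 nM
compound 2 `O=C(NC[C@H](NS(=O)(=O)c1ccccc1)C(=O)O)c1ccc2c(c1)C(=O)N(CCC1CCNCC1)C2` — 8 nM

In a functional assay for inhibition, with Homo sapiens as the target (a lower number here means a stronger inhibitor, a higher number a weaker inhibitor), compound 1 gives 8 nM, and compound 2 gives 8 nM. Compound 1 stands level with compound 2 at the digits shown; the one measured step, no change at the digits printed from compound 1 to compound 2 (within the scatter), exchanges phenyl for 2-ethoxyethyl on a sulfonyl sulfur and stays within the scatter.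

Compound 3 `O=C(NC[C@H](NS(=O)(=O)Cc1ccccc1)C(=O)O)c1ccc2c(c1)C(=O)N(CCC1CCNCC1)C2` differs from compound 1 as follows: phenyl in place of ethoxymethyl on a saturated chain carbon bound to a sulfonyl sulfur. Cut one bond further out, this reads 2-ethoxyethyl to benzyl, so compound 3 carries a benzylsulfonyl group where compound 1 carries a (2-ethoxyethyl)sulfonyl group. Among the measured compounds shown here, only the step from compound 1 to compound 2 bears on this change, and it showed no movement beyond the scatter, so the step of a 1.1-fold higher number from compound 1 to compound 3 (0.05 log units; within the scatter) is expected to be none beyond the scatter. Compound 3 is therefore estimated at 9 nM, with a range of 3 nM to 25 nM.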

Compound 3, half-maximal inhibitory concentration: 4 nM
Beside the measured number, compound 3's estimate is 2.3-fold (0.35 log units) above it, and the stated range covers the measured number.
By their numbers in this assay, from the lowest: compounds 3, 1 and 2 (each within the scatter of the next).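

In this assay, the third group on the sulfonyl sulfur also fails to separate from the others, and both new steps lie within the scatter (a 2.0-fold lower number from compound 1 to compound 3 (0.30 log units; within the scatter); a 2.0-fold lower number from compound 2 to compound 3 (0.30 log units; within the scatter)). The earlier pair had shown this only for phenyl and 2-ethoxyethyl, whereas benzyl adds a case in which the phenyl sits on a saturated chain carbon bound to a sulfonyl sulfur. Nothing else reported here bears on this result.

With all three compounds within the scatter of one another, the shown groups mark no limit to what this position accepts. From the compounds shown here alone, whether a longer chain such as 2-phenylethyl, or a chain ending in an amine or a carboxylic acid, would also stay within the scatter remains open.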